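Working notes on tolerated concentration across three analogues

The compounds below may be only part of what the source reports. "The series", "measured", "known", "first", "only" and "open" are said of these compounds alone.

Measured so far:
compound 1 `COC(=O)CNC1=CS(=O)(=O)O[C@@]12[C@@H](CO[Si](C)(C)C(C)(C)C)O[C@@H](n1cc(C)c(=O)n(C)c1=O)[C@@H]2O[Si](C)(C)C(C)(C)C`: 105000 nM
compound 2 `COC(=O)CC(=O)NC1=CS(=O)(=O)O[C@@]12[C@@H](CO[Si](C)(C)C(C)(C)C)O[C@@H](n1cc(C)c(=O)n(C)c1=O)[C@@H]2O[Si](C)(C)C(C)(C)C`: 11900 nM
compound 3 `Cc1cn([C@@H]2O[C@H](CO[Si](C)(C)C(C)(C)C)[C@@]3(OS(=O)(=O)C=C3NCC(=O)OCc3ccccc3)[C@H]2O[Si](C)(C)C(C)(C)C)c(=O)n(C)c1=O`: 250000 nM

In a functional assay on MT4 cells (Homo sapiens) (a lower number here means that less compound is tolerated, a higher number that more compound is tolerated), compound 3 gives the highest of the three numbers; compound 1 comes nearest and compound 2 lies furthest, with a 2.4-fold higher number from compound 1 to compound 3 (0.38 log units; beyond the scatter) and a 21-fold higher number from compound 2 to compound 3 (1.32 log units; beyond the scatter) both beyond the scatter. Compound 4 `COC(=O)CCNC1=CS(=O)(=O)O[C@@]12[C@@H](CO[Si](C)(C)C(C)(C)C)O[C@@H](n1cc(C)c(=O)n(C)c1=O)[C@@H]2O[Si](C)(C)C(C)(C)C` is unmeasured. It differs from compound 3 as follows: (methoxycarbonyl)methyl in place of benzyloxycarbonyl on a saturated chain carbon bound to an amine nitrogen. The step of a 2.4-fold higher number from compound 1 to compound 3 (0.38 log units; beyond the scatter) bears on this change most closely, since compound 4 carries an ester like compound 1 rather than the amide of compound 2; the large step of a 21-fold higher number from compound 2 to compound 3 (1.32 log units; beyond the scatter) runs in the other direction and is not expected to apply. A modest lower number is therefore expected, a 2.3-fold lower number from compound 3 to compound 4 (0.36 log units; beyond the scatter). Compound 4 is estimated at 110000 nM, within 40000 nM to 250000 nM.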

Compound 4, half-maximal cytotoxic concentration: > 250000 nM
Compound 4 was reported as a limit; the forecaster's own chance of this, stated with the estimate: 15%; at least 2.2-fold (0.35 log units) between middle value and limit.
By their numbers in this assay, from the lowest: compound 2; then compound 1; then compound 3.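

In this assay compound 4 is reported as a limit, > 250000 nM, not as a number. With 2-(methoxycarbonyl)ethyl on the amine nitrogen, the series shows an at least 2.3-fold higher number from compound 1 to compound 4 (0.37 log units; beyond the scatter) and an at least 21-fold higher number from compound 2 to compound 4 (1.32 log units; beyond the scatter), so a methyl ester chain now reaches the top of the readable range without any benzyl ester. The remaining step is a number no lower from compound 3 to compound 4 (the limit leaves the size open) and the two stand together at the ceiling: the limit of > 250000 nM in this assay, at which 1 of the 4 values shown sits.

On these data alone, the true value of compound 4 remains open. So does whether a carboxylic acid or a longer chain in place of 2-(methoxycarbonyl)ethyl would keep the number this high.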